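The compounds below may be only part of what the source reports. "The series", "measured", "known", "first", "only" and "open" are said of these compounds alone.

Measured so far in an assay on membranes from HeLa cells for displacement of a labelled ligand from adenosine receptor A3 (Homo sapiens), read by scintillation counting, with a stated time of 180 min, tested at 1 uM; a higher number here means more inhibition at the concentration tested (going by the name of the read-out), a lower number less inhibition:
- compound 1, `CCCOC(=O)C1=C(C)N(C)C(=O)NC1c1ccsc1`, gives 11%
- compound 2, `CC1=C(C(=O)OCC(C)C)C(c2ccsc2)NC(=O)N1C`, gives 4%
- compound 3, `CCCC(=O)C1=C(C)NC(=O)NC1c1ccoc1`, gives 2%

Compound 2 differs from compound 1 by methyl in place of hydrogen on a saturated chain carbon bound to two saturated chain carbons. The step in this assay is a number 7 percentage points lower from compound 1 to compound 2 (within the scatter), so the two values cannot be told apart. Compound 3 carries another core; the difference between the two cores is not broken down here, and all three measured values sit within the scatter of one another, so no order among them can be read.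

Compound 4, `CC1=C(C(=O)CC(C)C)C(c2ccoc2)NC(=O)N1`, is not yet measured. It differs from compound 3 by methyl in place of hydrogen on a saturated chain carbon bound to two saturated chain carbons, the same change as from compound 1 to compound 2, at the same kind of place in both. The change occurs only twice among these compounds, and the one measured instance gave no step beyond the scatter. The expected step for compound 4 is therefore small, no change at the digits printed from compound 3 to compound 4 (within the scatter), resting on compound 3 at 2% and on the earlier step of a number 7 percentage points lower from compound 1 to compound 2 (within the scatter). For compound 4 the estimate in this assay is 2%, expected to fall between 0% and 12%.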

Compound 4, a percentage reported as inhibition, at one concentration (the size of the read-out at that concentration, not a potency): 18%
Compound 4: middle estimate off by 16 percentage points, on the low side; measured number above the stated range.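

In this assay, adding the methyl to the chain gives a number 16 percentage points higher from compound 3 to compound 4 (beyond the scatter), and the same change does not carry over as a fixed step from one core to the other: the same change on two cores in this assay, a number 7 percentage points lower (within the scatter) from compound 1 to compound 2 and a number 16 percentage points higher (beyond the scatter) from compound 3 to compound 4, 23 percentage points apart, beyond the scatter of two such steps

Among these compounds, on these two pairs the outcome of the change differs with the core, but each core supplies only one pair, so this is no general rule for the series. The cores differ in more than one place, and the data do not show which part of the core of compound 3 goes with the higher number; compound 4 at 18% also gives a read-out at one concentration, not a potency.

Open, going by these compounds, is whether a longer chain, or a chain ending in an amine, in place of the isobutylcarbonyl group would take the number on the core of compound 3 higher still. Also open, on these data alone, is what each single difference between the cores does when the isobutyl group is held fixed.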